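Swapping one group on a shared core

The source may report more compounds than this note shows. Statements on the series, on what has been measured and on what is new or still open speak of the compounds shown alone.

In a functional assay on KBVIN cells (Homo sapiens) for antiproliferative activity, read by sulforhodamine B assay, with a stated time of 3 days (a lower number here means that less compound is needed, a higher number that more compound is needed for the effect), compound 1 `CCC1=C(O)c2c(oc(-c3ccc(CC)cc3)cc2=O)C(CC)(CC)C1=O` gives 0.07 uM and compound 2 `CCC1=C(O)c2c(oc(-c3ccc(OC)c(Cl)c3)cc2=O)C(CC)(CC)C1=O` gives 1.37 uM, so compound 2 holds the higher of the two numbers. Compound 3 `CCC1=C(O)c2c(oc(-c3ccc(O)c(C)c3C)cc2=O)C(CC)(CC)C1=O` keeps the same core and differs from compound 2 in one group: 4-hydroxy-2,3-dimethylphenyl in place of 3-chloro-4-methoxyphenyl on an aromatic carbon. In words, 4-hydroxy-2,3-dimethylphenyl takes the place of 3-chloro-4-methoxyphenyl on an aromatic carbon next to the ring oxygen. For the measured compounds named here, the only measured step at this place is a 20-fold higher number from compound 1 to compound 2 (1.29 log units; beyond the scatter), a large change showing that the number can move strongly here. Going by the values given here, neither group in that step is the one entering compound 3, so it points in no clear direction. A wide range is therefore needed, and no shift beyond the scatter is expected. The expected change is a 1.1-fold higher number from compound 2 to compound 3 (0.04 log units; within the scatter). For compound 3, the estimated value in this assay is 1.5 uM, within a range of 0.25 uM to 7 uM.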

Compound 3, concentration for half-maximal effect: 2.75 uM
Compound 3: the middle estimate sits 1.8-fold (0.26 log units) below what was measured; low and high end bracket the measured number.
By their numbers in this assay, from the lowest: compound 1; then compounds 2 and 3 (each within the scatter of the next).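

Measured in this assay the swap gives a 2.0-fold higher number from compound 2 to compound 3 (0.30 log units; within the scatter) even though the entering 4-hydroxy-2,3-dimethylphenyl brings a hydrogen-bond donor and leaves no chlorine, so these two differently substituted groups cannot be told apart here. Compared with 4-ethylphenyl, the same group gives a 39-fold higher number from compound 1 to compound 3 (1.59 log units; beyond the scatter) and so stands well apart from compound 1, which means the large gap at this position no longer rests on compound 2 alone. Nothing available explains why the number moves at this position.

With only three groups shown, it remains open whether the ethyl group itself matters or whether the extra substituents on the other two rings do. A plain phenyl, a propyl chain in place of the ethyl or an amine at that spot could help separate these possibilities.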